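A few compounds are considered here, and "the series" means these few. Any claim that something is new, unique, unknown or untested is made for them only; others in the source may bear on it.

Measured so far:
compound 1 `COc1cccc(Cc2cc(-c3ccc(F)cc3)nn(CC(=O)Nc3ccc(F)cc3)c2=O)c1`: > 50000 nM
compound 2 `Cc1cc(Cc2ccc(C(F)(F)F)cc2)c(=O)n(CC(=O)Nc2ccc(Br)cc2)n1`: > 50000 nM

In an assay on HL-60 cells for agonist activity at N-formyl peptide receptor 3 (Homo sapiens), read by calcium flux (a lower number here means that less compound is needed, a higher number that more compound is needed for the effect), compound 2 gives > 50000 nM, which is a limit of the assay and not a number. Compound 1 likewise gives > 50000 nM in this assay, again a limit. Among the compounds with values here, both values shown sit at the same limit (the limit of > 50000 nM in this assay, at which 2 of the 2 values shown sit), so compound 2 stands nowhere on a scale of numbers, only at the limit, and no step between measured compounds can be drawn from these two.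

Compound 3 `Cc1cc(Cc2cccnc2)c(=O)n(CC(=O)Nc2ccc(Br)cc2)n1` differs from compound 2 by pyridin-3-yl in place of 4-(trifluoromethyl)phenyl on a saturated chain carbon bound to an aromatic carbon. Within the data shown here, with no measured step to lean on, no size or direction of change in this assay beyond the scatter can be argued; the expectation is simply that compound 3 remains at or near the limit. Compound 3 is expected to give about 60000 nM in this assay, with a range of 8000 nM to 300000 nM. The step expected is a step that the limit leaves unreadable from compound 2 to compound 3, none beyond the scatter.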

Compound 3, half-maximal effective concentration: > 50000 nM
Compound 3 gave a limit, no number; the forecaster's own chance of this, stated with the estimate: 80%; the middle value lies beyond the limit too.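

Within the data shown here, compound 2 and compound 3 both give limits and not numbers in this assay and no step between them can be read. The compounds shown leave open whether any change on the shared core brings a value inside the measurable range.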